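The source may report more compounds than this note shows. Statements on the series, on what has been measured and on what is new or still open speak of the compounds shown alone.

In an ADME assay on microsomes from liver (Mus musculus) for metabolic stability, read by LC-MS, with a stated time of 10 min (a lower number here means that less of the compound is left, a higher number that more of the compound is left), compound 1 (`CCCN(C[C@H]1Cc2c(cccc2N2CCNCC2)CN1)[C@H]1CCCc2cccnc21`) gives 87.4% and compound 2 (`CN(C[C@H]1Cc2c(cccc2N2C[C@H]3C[C@@H]2CN3)CN1)[C@H]1CCCc2cccnc21`) gives 95.9%. These two values lie within the scatter of each other, so compound 2 does not stand apart from compound 1. Compound 3 (`CN(C[C@H]1Cc2c(cccc2N2CCNCC2)CN1)[C@H]1CCCc2cccnc21`) has not yet been measured. It differs from compound 2 on an aromatic carbon: a group of 6 heavy atoms (4 carbon, 2 nitrogen; one six-membered non-aromatic ring with 2 hetero atoms) in place of a group of 7 heavy atoms (5 carbon, 2 nitrogen; 2 five-membered non-aromatic rings with 1 hetero atom each), on an aromatic carbon. Within the data shown here, no measured step covers this change, so only a small downward move, not beyond the scatter, is expected, with an estimated a number 5.9 percentage points lower from compound 2 to compound 3 (within the scatter). For compound 3 the expected value is 90%, with an estimated range of 79% to 98%.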

Compound 3, percent of the compound remaining: 19.9%
Estimate against measurement, compound 3: 70.1 percentage points above; measured number below the stated range.
By their numbers in this assay, from the lowest: compound 3; then compounds 1 and 2 (each within the scatter of the next).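

In this assay, the group on the aromatic carbon carries a large effect: piperazin-1-yl in place of the group with two five-membered rings gives a number 76 percentage points lower from compound 2 to compound 3 (beyond the scatter). With piperazin-1-yl held fixed, the chain on the amine nitrogen also matters: hydrogen in place of ethyl on the saturated chain carbon gives a number 67.5 percentage points lower from compound 1 to compound 3 (beyond the scatter). Nothing available accounts for either step. Open, from the compounds shown here alone, is how an ethyl chain on that amine nitrogen would read in this assay, and whether morpholine on the aromatic carbon would behave like piperazin-1-yl.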